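Trading the benzylamine linker for an aryl thioether

The source may hold more compounds than are shown below. What is called first, only, known or untested is meant among the compounds shown, and "the series" means these compounds.

Compound 1 `Nc1cc(N)c2nc(-c3ccccc3)c(NCc3ccc(Cl)c(Cl)c3)nc2c1` gives 17400 nM in a functional assay on A498 cells (Homo sapiens) for inhibition, read by sulforhodamine B assay, with a stated time of 48 h; a higher number here means a weaker inhibitor of growth, a lower number a stronger inhibitor of growth. Compound 2 `Nc1cc(N)c2nc(-c3ccccc3)c(NCc3ccc(F)cc3)nc2c1` gives 17000 nM in this assay, and the two sit level, as a 1.0-fold lower number from compound 1 to compound 2 (0.01 log units; within the scatter) shows. Compound 3 `COc1ccc(CNc2nc3cc(N)cc(N)c3nc2-c2ccccc2)cc1` reaches only a limit of this assay, < 100000 nM. Compound 4 `Nc1cc(N)c2nc(-c3ccccc3)c(Sc3ccc(Cl)c(Cl)c3)nc2c1` differs from compound 2 by (3,4-dichlorophenyl)sulfanyl in place of (4-fluorobenzyl)amino on an aromatic carbon. For the measured compounds named here, the only readable step, a 1.0-fold lower number from compound 1 to compound 2 (0.01 log units; within the scatter), changed just the substituent on the benzyl ring; the steps a step that the limit leaves unreadable from compound 1 to compound 3 and a step that the limit leaves unreadable from compound 2 to compound 3 cannot be sized, and no measured pair alters the linker itself. The step to compound 4 is therefore expected to be a 1.2-fold higher number from compound 2 to compound 4 (0.07 log units; within the scatter), nothing beyond the scatter. Compound 4 is estimated at 20000 nM, between 5000 nM and 80000 nM.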

Compound 4, concentration for 50% growth inhibition: 17000 nM
The estimate for compound 4 lay 1.2-fold (0.07 log units) above the measured number; measured number inside the range.
By their numbers in this assay, from the lowest: compounds 2, 4 and 1 (each within the scatter of the next).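

Replacing the (4-fluorobenzyl)amino group with (3,4-dichlorophenyl)sulfanyl on the aromatic carbon next to the ring nitrogen gives no change at the digits printed from compound 2 to compound 4 (within the scatter) in this assay. For the compounds shown here, this is the first change to the linker itself, and the number stays level even though the entering group has no hydrogen-bond donor, so growth inhibition here does not depend on that donor. Nothing measured here explains why the number holds.

As far as these compounds go, it remains open whether a longer chain between the sulfur and the ring, or a carboxylic acid on that ring, would shift the number beyond the scatter.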